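Cytotoxicity of a shared core with varied amine substituents

The compounds below may be only part of what the source reports. "The series", "measured", "known", "first", "only" and "open" are said of these compounds alone.

In an ADME assay on HepG2 2.2.15 cells (Homo sapiens) for cytotoxicity (a higher number here means that more compound is tolerated, a lower number that less compound is tolerated), compound 1 `CC(C)(C)OC(=O)Nc1ncc(C(Oc2ccc3cc(Br)ccc3c2)c2ccc(Cl)cc2)s1` reports only a limit of > 50000 nM. Compound 2 `COCCCNc1ncc(C(Oc2ccc3cc(Br)ccc3c2)c2ccc(Cl)cc2)s1` is recorded in this assay as "not toxic" (no number reported). Compound 3 `Clc1ccc(C(Oc2ccc3cc(Br)ccc3c2)c2cnc(NCC3CCOCC3)s2)cc1` is also recorded in this assay as "not toxic" (no number reported), so no single number places it; among the three values shown, one sits at the limit of > 50000 nM in this assay, at which 1 of the 3 values shown sits, and the other two carry no number at all. Compound 4 `O=C(Nc1ncc(C(Oc2ccc3cc(Br)ccc3c2)c2ccc(Cl)cc2)s1)C1CC1` differs from compound 3 by cyclopropylcarbonyl in place of (oxan-4-yl)methyl on a nitrogen on an aromatic ring. For the measured compounds named here, no step between measured compounds is known, so with all three values pointing to tolerance at the top of the range, no shift beyond the scatter is expected in this assay. Compound 4 is estimated at 50000 nM, within 20000 nM to 100000 nM.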

Compound 4, half-maximal cytotoxic concentration: "not toxic" (no number reported)
Compound 4 has no reported number here, and the estimate cannot be compared.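

For the compounds shown here, compound 3 and compound 4 both stand as "not toxic" without a number, so no step between them can be read. The compounds shown leave open whether any substituent on this nitrogen changes tolerance in this assay, where the only figure is the limit of compound 1: the limit of > 50000 nM in this assay, at which 1 of the 4 values shown sits.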